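Swapping the Urea Aryl: Compound 2 to Compound 3

The source may hold more compounds than are shown below. What is called first, only, known or untested is meant among the compounds shown, and "the series" means these compounds.

Of the compounds shown here, two sharing one core have been tested in a functional assay on NCI-H520 cells (Homo sapiens) for inhibition, read by MTT assay, with a stated time of 48 h, tested at 10 uM; on this read-out higher numbers stand for more inhibition at the one concentration tested (going by the name of the read-out) and lower numbers for less inhibition. Compound 1, `COc1cc(NC(=O)Nc2cc(Nc3cccc(C(C)(C)C)c3)ncn2)cc(OC)c1`, gives 13.1% in this assay. Compound 2, `COc1ccc(Nc2cc(NC(=O)Nc3c(Cl)cccc3Cl)ncn2)cc1C`, gives 29.1% in this assay, the higher of the two numbers; the gap to compound 1 lies beyond the scatter of repeated measurements, so the inhibition of compound 2 in this assay is the higher of the pair.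

Compound 3, `COc1cc(NC(=O)Nc2cc(Nc3ccc(OC)c(C)c3)ncn2)cc(OC)c1`, differs from compound 2 in one place: 3,5-dimethoxyphenyl in place of 2,6-dichlorophenyl on an amide-type nitrogen. The group that enters is the same 3,5-dimethoxyphenyl that compound 1 carries on its amide-type nitrogen, while the rest of compound 3 follows compound 2.

For the measured compounds named here, no measured step between two compounds differing in just one place is available, so the size of this step cannot be read from the data. Because compound 1, which also carries the 3,5-dimethoxyphenyl, gives only 13.1%, a downward step of a number 12.1 percentage points lower from compound 2 to compound 3 (beyond the scatter) is expected. Compound 3 is therefore estimated to give 17%, with a range from 5% to 32%.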

Compound 3, a percentage reported as inhibition, at one concentration (the size of the read-out at that concentration, not a potency): 13.5%
The estimate for compound 3 lay 3.5 percentage points above the measured number; low and high end bracket the measured number.
By their numbers in this assay, from the lowest: compounds 1 and 3 (each within the scatter of the next); then compound 2.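

In this assay, putting 3,5-dimethoxyphenyl in place of 2,6-dichlorophenyl on the amide-type nitrogen gives a number 15.6 percentage points lower from compound 2 to compound 3 (beyond the scatter), the first size that can be read for a change at this position with the rest of the molecule held constant. The other new comparison concerns a different place, a nitrogen on an aromatic ring, where 4-methoxy-3-methylphenyl stands in place of 3-(tert-butyl)phenyl and gives a number 0.4 percentage points higher from compound 1 to compound 3 (within the scatter), so with 3,5-dimethoxyphenyl on the amide-type nitrogen these two groups cannot be told apart on this read-out. Nothing available explains why the number drops with the change on the amide-type nitrogen.

As far as these compounds go, the step swaps two chlorine atoms and their placement for two methoxy groups and their placement all at once, so it remains open which of these differences goes with the lower number. An unsubstituted phenyl, a 3,5-dichlorophenyl or a 2,6-dimethoxyphenyl on the same nitrogen could separate those differences, while 2,6-dichlorophenyl paired with 3-(tert-butyl)phenyl on the shared core would test whether the two places act independently.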